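Swapping a Ring for a Urea: Solubility of Compound 4

This account rests on a few compounds, and the source may have more. Where it says the series, first, only, none or still open, it means among the compounds named here.

Compound 1 `CCN1CCN(C[C@H]2CN(c3ccc(-n4cc(-c5ccccn5)cn4)c(F)c3)C(=O)O2)CC1` gives 706000 nM in a physicochemical assay for solubility, read by HPLC, with a stated time of 24 h; a lower number here means a less soluble compound, a higher number a more soluble compound.
Compound 2 `O=C1CSC(=O)N1C[C@H]1CN(c2ccc(-n3cc(-c4ccccn4)cn3)c(F)c2)C(=O)O1` gives 26900 nM in this assay.
Compound 3 `COC(=O)NC[C@H]1CN(c2ccc(-n3cc(-c4ccccn4)cn3)c(F)c2)C(=O)O1` gives 34100 nM in this assay.

Compound 2 stands lowest of these three numbers in this assay. Its nearest neighbour is compound 3, separated by a 1.3-fold higher number from compound 2 to compound 3 (0.10 log units; within the scatter); its furthest is compound 1, separated by a 26-fold lower number from compound 1 to compound 2 (1.42 log units; beyond the scatter).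

Compound 4 `CCNC(=O)NC[C@H]1CN(c2ccc(-n3cc(-c4ccccn4)cn3)c(F)c2)C(=O)O1` has not yet been measured. It differs from compound 2 in one place: (ethylcarbamoyl)amino in place of 2,4-dioxo-1,3-thiazolidin-3-yl on a saturated chain carbon bound to a saturated ring carbon

Two kinds of measured step bear on this. Removing 4-ethylpiperazin-1-yl produced large drops, a 26-fold lower number from compound 1 to compound 2 (1.42 log units; beyond the scatter) and a 21-fold lower number from compound 1 to compound 3 (1.32 log units; beyond the scatter), but neither compound 2 nor compound 4 carries that group, so those steps only set the level from which compound 4 starts. The closer guide is the exchange of 2,4-dioxo-1,3-thiazolidin-3-yl for (methoxycarbonyl)amino, a 1.3-fold higher number from compound 2 to compound 3 (0.10 log units; within the scatter), which stayed within the scatter. The (ethylcarbamoyl)amino group entering compound 4, like (methoxycarbonyl)amino, brings no ring and is similar in size, so a step of the same small kind is expected: a 1.3-fold higher number from compound 2 to compound 4 (0.11 log units; within the scatter), within the scatter and leaning, if anywhere, slightly upward. Compound 4 is therefore estimated at 35000 nM in this assay, with a range from 14000 nM to 85000 nM.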

Compound 4, solubility: 222000 nM
Compound 4: the middle estimate sits 6.3-fold (0.80 log units) below what was measured; measured number outside the range, above it.
By their numbers in this assay, from the lowest: compounds 2 and 3 (each within the scatter of the next); then compound 4; then compound 1.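

In this assay, the position on a saturated chain carbon bound to a saturated ring carbon proved more sensitive than the first three compounds suggested: (ethylcarbamoyl)amino in place of 2,4-dioxo-1,3-thiazolidin-3-yl gives an 8.3-fold higher number from compound 2 to compound 4 (0.92 log units; beyond the scatter) and lies beyond the scatter. Losing the ring cannot alone account for this, since compound 3 also has no ring there and stays within the scatter of compound 2, whereas ethylamino in place of methoxy on a carbonyl carbon gives a 6.5-fold higher number from compound 3 to compound 4 (0.81 log units; beyond the scatter) as a modest step. The new group still does not match 4-ethylpiperazin-1-yl, with a 3.2-fold lower number from compound 1 to compound 4 (0.50 log units; beyond the scatter) remaining beyond the scatter, so compound 4 sits between the low pair and compound 1.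

The compounds shown offer no evidence on why ethylamino and methoxy differ so much on this carbonyl carbon. On these data alone, it also remains open whether a plain amino group, a dimethylamino group or a longer chain such as propylamino on the same carbonyl carbon would give a number nearer compound 4 or nearer compound 3.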